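Exchanging Cyclobutyloxy for Azetidinyl on the Shared Core

The compounds below may be only part of what the source reports. "The series", "measured", "known", "first", "only" and "open" are said of these compounds alone.

Measured compounds:
compound 1 `CCCCCCCCCCCCCCc1nc(N2CCC2)nc(OC2CCC2)c1O`: 102%
compound 2 `CCCCCCCCCCCCCCc1nc(OC2CCC2)nc(N2CCC2)c1O`: 105%
compound 3 `CCCCCCCCCCCCCCCCc1nc(OC2CCC2)nc(N2CCC2)c1O`: 110%

In a functional assay on cells (Lymphocyte, Homo sapiens), read by a luciferase reporter and ATP content, with a stated time of 48 h, tested at 5 uM (on this read-out higher numbers stand for a weaker effect at the one concentration tested and lower numbers for a stronger effect), compound 2 stands second highest of the three numbers. Its nearest neighbour is compound 1, whose value is a few points lower and within the scatter; the furthest is compound 3, whose value sits a few points higher, also within the scatter. All three numbers therefore describe compounds with no clear effect at the single concentration tested.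

Compound 4 `CCCCCCCCCCCCCCc1nc(N2CCC2)nc(N2CCC2)c1O` has not yet been measured. It differs from compound 2 in one place: azetidin-1-yl in place of cyclobutyloxy on an aromatic carbon.

Among the measured compounds shown here, only one measured step is at hand, and it does not touch the aromatic ring: lengthening the saturated chain gave a number 5 percentage points higher from compound 2 to compound 3 (within the scatter). For the measured compounds named here, no measured pair shows what replacing cyclobutyloxy by azetidin-1-yl does, so nothing points to a change beyond the scatter. The step of a number 1 percentage points lower from compound 2 to compound 4 (within the scatter) is therefore expected to be small. For compound 4 a value of 104% is estimated, in the range 90% to 118%.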

Compound 4, a percentage reported as activity, at one concentration (the size of the read-out at that concentration, not a potency): 46%
Compound 4: the middle estimate sits 58 percentage points above what was measured, outside the stated range (below it).
By their numbers in this assay, from the lowest: compound 4; then compounds 1, 2 and 3 (each within the scatter of the next).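

Azetidin-1-yl in place of cyclobutyloxy on the aromatic carbon between two ring nitrogen atoms gives a number 59 percentage points lower from compound 2 to compound 4 (beyond the scatter) in this assay, the first step in this set to lie beyond the scatter. The same exchange at the other ring carbon carrying cyclobutyloxy, in compound 1, gives a number 56 percentage points lower from compound 1 to compound 4 (beyond the scatter), so this exchange matters at both places. Compounds 1 and 2 each pair one azetidin-1-yl with one cyclobutyloxy and lie within the scatter of each other, whereas compound 4, with azetidin-1-yl at both places, stands clearly lower than either.

The data offer no measured cause for this drop. Still open, on these data alone, is whether another amine, such as pyrrolidin-1-yl or dimethylamino, would act like azetidin-1-yl at these places, and how a longer chain on compound 4 would read.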